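A few compounds are considered here, and "the series" means these few. Any claim that something is new, unique, unknown or untested is made for them only; others in the source may bear on it.

Measured compounds:
Compound 1, `Cc1ccccc1-c1cccc(COc2ccc([C@H](CC(=O)O)c3nccn3C)cc2)c1`: 89000 nM
Compound 2, `Cc1c(Cl)cccc1-c1cccc(COc2ccc([C@H](CC(=O)O)c3nccn3C)cc2)c1`: 22000 nM

In an assay on CHO cells for agonist activity at Free fatty acid receptor 1 (Homo sapiens), read by luminescence, with a stated time of 20 s, in the presence of a further agent that is not named here (on this read-out lower numbers stand for an effect already at smaller amounts and higher numbers for an effect only at larger amounts of compound), compound 1 gives 89000 nM, while compound 2 gives 22000 nM. For the measured compounds named here, the only measured step is a 4.0-fold lower number from compound 1 to compound 2 (0.61 log units; beyond the scatter), so compound 2 stands at the lowest of the two numbers seen so far, and its nearest neighbour is compound 1 at the higher end.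

Compound 3, `Cc1cc(Cl)ccc1-c1cccc(COc2ccc([C@H](CC(=O)O)c3nccn3C)cc2)c1`, differs from compound 2 by 4-chloro-2-methylphenyl in place of 3-chloro-2-methylphenyl on an aromatic carbon. Going by the values given here, no measured step compares two placements of the chloro on this ring; the step from compound 1 to compound 2 shows only that introducing the chloro at one position moved the number by a modest amount, and it does not say whether a different position would hold that gain, enlarge it or lose it. With the same atoms merely rearranged, a step within the scatter, or a small one in either direction, is the most defensible expectation, with some risk of drifting back toward the number of compound 1.

Compound 3 is therefore estimated to give 25000 nM, within a range of 8000 nM to 70000 nM. This expected outcome corresponds to a step of a 1.1-fold higher number from compound 2 to compound 3 (0.06 log units; within the scatter).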

Compound 3, half-maximal effective concentration: 10000 nM
Compound 3: middle estimate off by 2.5-fold (0.40 log units), on the high side; the measured number falls inside the stated range.
By their numbers in this assay, from the lowest: compound 3; then compound 2; then compound 1.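

In this assay, where the chloro sits on this ring counts for something: with the atoms unchanged, 4-chloro-2-methylphenyl in place of 3-chloro-2-methylphenyl gives a 2.2-fold lower number from compound 2 to compound 3 (0.34 log units; beyond the scatter), a step beyond the scatter, so the earlier gain from adding chloro was not the most this ring could give among the compounds shown. Set against the ring without chloro, the new placement gives an 8.9-fold lower number from compound 1 to compound 3 (0.95 log units; beyond the scatter), compared with a 4.0-fold lower number from compound 1 to compound 2 (0.61 log units; beyond the scatter) for the earlier placement, which shows that the size of the gain from chloro depends on its place and not on its presence alone. No measurement shown here accounts for the difference between the two placements.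

The compounds shown leave open whether bromo, methoxy or trifluoromethyl in place of the chloro of 4-chloro-2-methylphenyl would keep, extend or lose this gain, and whether the methyl of that group contributes to it at all. They also leave open how much lower the number can go from compound 3, which still gives 10000 nM, through changes elsewhere on the shared core, such as an amine or a longer chain.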